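This account rests on a few compounds, and the source may have more. Where it says the series, first, only, none or still open, it means among the compounds named here.

Measured compounds in a functional assay on the whole organism (liver, strain NMRI) for inhibition, with Mus musculus as the target, with a stated time of 3 h, at a dose of 3 mg/kg by the oral route; a lower number here means less inhibition, a higher number more inhibition at the dose given (going by the name of the read-out):
- compound 1 `O=[N+]([O-])c1cc(-c2nc(N3CCN(c4ccccn4)CC3)no2)cc(O)c1O` gives 32.2%
- compound 2 `CC(=O)N1CCN(c2noc(-c3cc(O)c(O)c([N+](=O)[O-])c3)n2)CC1` gives 68.2%
- compound 3 `O=[N+]([O-])c1cc(-c2cc(-c3ccncc3)no2)cc(O)c1O` gives 32.1%

Compound 3 has the lowest of the three numbers, but compound 1 sits within the scatter of it, so the two cannot be ranked; only compound 2 stands clearly higher. Among the measured compounds shown here, the single measured step, a number 36 percentage points higher from compound 1 to compound 2 (beyond the scatter), concerns a change on an amine nitrogen in a ring and so says nothing about the change now in question. Compound 4 `O=[N+]([O-])c1cc(-c2cc(-c3cnccn3)no2)cc(O)c1O` differs from compound 3 by pyrazin-2-yl in place of pyridin-4-yl on an aromatic carbon. For the measured compounds named here, with no step bearing on this exchange, no movement beyond the scatter is expected, so compound 4 is estimated at 32% (range 14% to 52%), an expected step of a number 0.1 percentage points lower from compound 3 to compound 4 (within the scatter).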

Compound 4, a percentage reported as inhibition, in the whole organism at one dose (the size of the read-out at that dose, not a potency): 44.7%
For compound 4 the middle estimate is 12.7 percentage points below the measured one, and the stated range covers the measured number.
By their numbers in this assay, from the lowest: compounds 3 and 1 (each within the scatter of the next); then compound 4; then compound 2.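

At this position, on an aromatic carbon of the five-membered aromatic ring, the choice of attached ring affects the outcome in this assay: pyrazin-2-yl in place of pyridin-4-yl gives a number 12.6 percentage points higher from compound 3 to compound 4 (beyond the scatter). So exchanging one six-membered aromatic ring for another of equal heavy-atom count can move this read-out beyond the scatter. No available data say why the number moves. As far as these compounds go, whether the second ring nitrogen matters, or only where a ring nitrogen sits, stays open. So does what a phenyl ring or a small amine would give on this carbon.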